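This account rests on a few compounds, and the source may have more. Where it says the series, first, only, none or still open, it means among the compounds named here.

Measured compounds:
compound 1, `OCc1cc(OCc2cc(O)ccc2O)cc(Cl)c1O`, 14300 nM;
compound 2, `OCc1cc(OCc2cc(O)ccc2O)ccc1O`, 9600 nM;
compound 3, `COCc1cc(O)cc(Cl)c1O`, 56500 nM.

All three were run in a functional assay on A549 cells (Homo sapiens) for cytotoxicity, read by sulforhodamine B assay; on this read-out higher numbers stand for weaker inhibition and lower numbers for stronger inhibition. Compound 4, `COCc1cc(O)ccc1O`, is not yet measured. Compound 4 differs from compound 3 by hydrogen in place of chloro on an aromatic carbon. Compound 2 differs from compound 1 by hydrogen in place of chloro on an aromatic carbon; here the place is ortho to a hydroxy group, meta to a hydroxymethyl group and meta to a large group, whereas in compound 3 it is meta to a hydroxy group and meta to a methoxymethyl group, so the two are the same kind of change. How the core of compound 3 differs from that of compound 1 is not broken down here. The earlier step gave a 1.5-fold lower number from compound 1 to compound 2 (0.17 log units; within the scatter). A similar small step is expected for compound 4, a 1.4-fold lower number from compound 3 to compound 4 (0.15 log units; within the scatter), because compound 3 gives 56500 nM. Compound 4 is therefore estimated at 40000 nM, between 15000 nM and 110000 nM.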

Compound 4, half-maximal inhibitory concentration: > 100000 nM
Compound 4: only a limit was reported; the forecaster's own chance of this, stated with the estimate: 20%; at least 2.5-fold (0.39 log units) between middle value and limit.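

In this assay, hydrogen in place of chloro on the aromatic carbon gives an at least 1.7-fold higher number from compound 3 to compound 4 (0.24 log units; that floor lies within the scatter). The value of compound 4, > 100000 nM, is a limit of the assay and not a number. This shows only one side of the step on this core, and it neither shows that the change carries over from one core to the other nor shows that it does not: the same change on two cores in this assay, a 1.5-fold lower number (0.17 log units; within the scatter) from compound 1 to compound 2 and an at least 1.7-fold higher number (0.24 log units; that floor lies within the scatter) from compound 3 to compound 4; the limit leaves it open whether they differ

The compounds shown leave open whether fluoro, bromo or methoxy at this place would give a number apart from those of the chloro and hydrogen compounds. They also leave open what an amine or a carboxylic acid in place of the methoxymethyl group would give in this assay.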